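The source may hold more compounds than are shown below. What is called first, only, known or untested is meant among the compounds shown, and "the series" means these compounds.

Three measured compounds share a common core built around an indole-type framework carrying an aryl group and a substituted vinyl arm; the differences lie in the arm and in a ring substituent. Compound 1, `COc1ccc(-c2[nH]c3ccccc3c2/C=C(\C#N)S(=O)(=O)c2ccccc2)cc1`, was tested in a functional assay on HCC 2998 cells (Homo sapiens) for inhibition, read by sulforhodamine B assay, with a stated time of 48 h (on this read-out lower numbers stand for stronger inhibition of growth and higher numbers for weaker inhibition of growth), and gives 1200 nM, the lowest number of the three. Compound 2, `COc1ccc2[nH]c(-c3ccccc3)c(C=C(C#N)C#N)c2c1`, gives 6100 nM in this assay, a number well beyond the scatter above that of compound 1. Compound 3, `CCOC(=O)C(=Cc1c(-c2ccccc2)[nH]c2ccccc12)C(=O)OCC`, gives 10100 nM in this assay, the highest of the three, again beyond the scatter. No pair of these compounds differs in only one place, so no single structural step can be read off from them.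

Compound 4, `COc1ccc(-c2[nH]c3ccc(OC)cc3c2/C=C(\C#N)S(=O)(=O)c2ccccc2)cc1`, differs from compound 1 by one change: methoxy in place of hydrogen on an aromatic carbon, sitting meta to a fused ring and para to a fused ring on the six-membered carbon ring of the fused system. Nothing measured here shows what this change alone does, so an estimate for compound 4 in this assay can only lean on compound 1 and its value 1200 nM, and the step expected from compound 1 to compound 4 is a 1.3-fold higher number from compound 1 to compound 4 (0.10 log units; within the scatter), a change not expected to exceed the scatter. Compound 4 is therefore estimated at 1500 nM, with a range from 600 nM to 4000 nM.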

Compound 4, concentration for 50% growth inhibition: 2000 nM
For compound 4 the middle estimate is 1.3-fold (0.12 log units) below the measured one; measured number inside the range.
By their numbers in this assay, from the lowest: compounds 1 and 4 (each within the scatter of the next); then compounds 2 and 3 (each within the scatter of the next).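

In this assay, putting methoxy in place of hydrogen on an aromatic carbon, meta to a fused ring and para to a fused ring, gives a 1.7-fold higher number from compound 1 to compound 4 (0.22 log units; within the scatter) and so compound 1 and compound 4 cannot be told apart. This is the first step among these compounds that changes only one place, and it shows that this position on the core of compound 1 can carry methoxy with no difference beyond the usual spread of repeated measurements. Nothing available explains this result at the level of mechanism.

From the compounds shown here alone, whether a hydroxyl, an amine or a carboxylic acid at this place would also stay within the scatter remains open. So does whether methoxy here would behave the same way alongside the arm of compound 2 or compound 3.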